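What happens when the (carboxymethyl)amino group leaves?

The compounds below may be only part of what the source reports. "The series", "measured", "known", "first", "only" and "open" are said of these compounds alone.

For the measured compounds named here, in a functional assay on MCF7 cells (Homo sapiens) for antiproliferative activity (a higher number here means a weaker inhibitor, a lower number a stronger inhibitor), compound 3 `CC(C)=CCc1cc(C(=O)Nc2cc3ccc(OCCCNCC(=O)O)c(C)c3oc2=O)ccc1O` gives 18100 nM and is the weakest of the three compounds measured so far. Compound 1 `CCN(C)CCCOc1ccc2cc(NC(=O)c3ccc(O)c(CC=C(C)C)c3)c(=O)oc2c1C` gives 2190 nM there. Compound 2 `CC(C)=CCc1cc(C(=O)Nc2cc3ccc(OCCCN(C)C(C)(C)C)c(C)c3oc2=O)ccc1O` gives 1140 nM there, with a 1.9-fold lower number from compound 1 to compound 2 (0.28 log units; within the scatter) separating the two.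

Compound 4 `CC(C)=CCc1cc(C(=O)Nc2cc3ccc(OCCCN(C)c4ccccc4)c(C)c3oc2=O)ccc1O` is still unmeasured. It carries methyl(phenyl)amino in place of (carboxymethyl)amino on a saturated chain carbon, three bonds along the chain from an oxygen on an aromatic ring.

Going by the values given here, two measured steps bear on this change when read in reverse. The modest 8.3-fold higher number from compound 1 to compound 3 (0.92 log units; beyond the scatter) and the large 16-fold higher number from compound 2 to compound 3 (1.20 log units; beyond the scatter) both bring in the (carboxymethyl)amino group, so losing it should lower the number. Neither compound 1 nor compound 2 has a phenyl group on that nitrogen, so the range must stay wide. For compound 4 the expected change in this assay is a 9.1-fold lower number from compound 3 to compound 4 (0.96 log units; beyond the scatter) by this estimate, a step beyond the scatter. Compound 4 is expected at 2000 nM (700 nM to 6000 nM).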

Compound 4, half-maximal inhibitory concentration: > 50000 nM
Compound 4: only a limit was reported (the forecaster's own chance of this, stated with the estimate: 3%); at least 25-fold (1.39 log units) between middle value and limit.
By their numbers in this assay, from the lowest: compounds 2 and 1 (each within the scatter of the next); then compound 3. At a limit, above all of these: compound 4.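

In this assay compound 4 gives only a limit, > 50000 nM. Losing the (carboxymethyl)amino group therefore does not by itself lower the number at this position, since methyl(phenyl)amino gives an at least 2.7-fold higher number from compound 3 to compound 4 (0.44 log units; beyond the scatter). What the amine nitrogen carries matters more than compounds 1 and 2 suggested, with phenyl in place of tert-butyl giving an at least 43-fold higher number from compound 2 to compound 4 (1.64 log units; beyond the scatter) and phenyl in place of ethyl giving an at least 22-fold higher number from compound 1 to compound 4 (1.35 log units; beyond the scatter).

From the compounds shown here alone, how far the true number of compound 4 lies past its limit remains unknown, so these steps give only the smallest possible sizes. The compounds shown also leave open whether an aromatic ring on this nitrogen is the deciding feature, a question that a saturated cyclohexyl group or a benzyl group on the same nitrogen could help answer.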